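The compounds below may be only part of what the source reports. "The series", "measured", "known", "first", "only" and "open" are said of these compounds alone.

In a functional assay on PC-9 cells (Homo sapiens) for inhibition, read by MTT assay, with a stated time of 72 h (on this read-out lower numbers stand for stronger inhibition and higher numbers for weaker inhibition), compound 2 (`Cc1cc(Nc2ccn(Cc3ccccc3)n2)n2nc(SCc3ccc(Br)cc3)nc2n1`) gives > 50000 nM, which is a limit and not a number. Compound 3 (`C=CCSc1nc2nc(C)cc(Nc3cc(-c4ccccc4)[nH]n3)n2n1`) gives > 50000 nM, also a limit. Going by the values given here, compound 1 (`Cc1cc(Nc2cc(-c3ccccc3)[nH]n2)n2nc(SCc3ccc(F)cc3)nc2n1`) gives 8110 nM, the only true number so far.

Compound 4 (`Cc1cc(Nc2ccn(Cc3nc(C)c4ccccc4n3)n2)n2nc(SCc3ccc(Br)cc3)nc2n1`) carries one change from compound 2: 4-methylquinazolin-2-yl in place of phenyl on a saturated chain carbon bound to an aromatic nitrogen. Among the compounds with values here, the only measured step, an at least 6.1-fold higher number from compound 1 to compound 3 (0.78 log units; beyond the scatter), sits on a saturated chain carbon bound to a sulfur, so it offers a rough size only. A modest move toward a lower number in this assay is expected, though a second reading at the limit remains possible. The expected change is an at least 2.5-fold lower number from compound 2 to compound 4 (0.39 log units; beyond the scatter). For compound 4 the estimated value is 20000 nM, with an expected range of 5000 nM to 60000 nM.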

Compound 4, half-maximal inhibitory concentration: 5450 nM
Compound 4: the middle estimate sits 3.7-fold (0.56 log units) above what was measured; low and high end bracket the measured number.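

In this assay, 4-methylquinazolin-2-yl in place of phenyl on a saturated chain carbon bound to an aromatic nitrogen gives an at least 9.1-fold lower number from compound 2 to compound 4 (0.96 log units; beyond the scatter), the first step toward a lower number among the compounds shown. The group at this place can therefore bring the read-out off the limit. The full size of the step stays unknown because compound 2 stands at a limit: the limit of > 50000 nM in this assay, at which 2 of the 4 values shown sit.

Open, as far as these compounds go, is whether the step depends on the ring nitrogens, the methyl or the second ring. A naphthyl group or an unsubstituted quinazolin-2-yl at this place would help separate these.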